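Chloro for methyl on the sulfonamide aryl ring

The compounds below may be only part of what the source reports. "The series", "measured", "known", "first", "only" and "open" are said of these compounds alone.

Compound 1 `O=c1cc(Cn2cc(CCO)nn2)c2ccc(O)cc2o1` gives 90300 nM in a functional assay on A549 cells (Homo sapiens) for inhibition, read by MTT assay, with a stated time of 72 h; a higher number here means a weaker inhibitor, a lower number a stronger inhibitor.
Compound 2 `CC(O)c1cn(Cc2cc(=O)oc3cc(O)ccc23)nn1` reaches only the limit > 100000 nM in this assay.
Compound 3 `Cc1ccc(S(=O)(=O)NCc2cn(Cc3cc(=O)oc4cc(O)ccc34)nn2)cc1` gives 46400 nM in this assay.

Compound 2 sits at the limit of > 100000 nM in this assay, at which 1 of the 3 values shown sits. Among the two numbers shown, compound 3 carries the lowest, and compound 1 is its nearest neighbour at a gap that lies within the scatter, so no order between them is claimed. Among the compounds with values here, the one measured step, an at least 1.1-fold higher number from compound 1 to compound 2 (0.04 log units; that floor lies within the scatter), concerns hydroxyethyl groups and does not touch the sulfonamide aryl ring.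

Compound 4 `O=c1cc(Cn2cc(CNS(=O)(=O)c3ccc(Cl)cc3)nn2)c2ccc(O)cc2o1` differs from compound 3 by chloro in place of methyl on an aromatic carbon. Within the data shown here, no measured step bears on this exchange, so nothing in the data argues for a shift beyond the scatter in this assay in either direction. The expected step of a 1.0-fold lower number from compound 3 to compound 4 (0.00 log units; within the scatter) is therefore a flat one. For compound 4 the estimate in this assay is 46000 nM, expected to fall between 15000 nM and 140000 nM.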

Compound 4, half-maximal inhibitory concentration: 47900 nM
Compound 4: middle estimate off by 1.0-fold (0.02 log units), on the low side; low and high end bracket the measured number.
By their numbers in this assay, from the lowest: compounds 3, 4 and 1 (each within the scatter of the next). At a limit, above all of these: compound 2.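

Within the data shown here, the exchange of methyl for chloro on an aromatic carbon para to a large group gives a 1.0-fold higher number from compound 3 to compound 4 (0.01 log units; within the scatter) in this assay and so puts a first measured step at this position, where 4-methylphenyl and 4-chlorophenyl cannot be told apart. Among these compounds, the earlier compounds offered no such comparison, since their one step concerned hydroxyethyl groups and left the sulfonamide aryl ring untouched. Nothing in the data shown accounts for this flat step.

On these data alone, whether a different group at this place, such as an amine, a carboxylic acid or a methoxy group, would give a step beyond the scatter remains open. Also open, as far as these compounds go, is what a longer chain in place of the methyl would do, and whether other carbons of the same ring would respond as this one does.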